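Bromo in place of difluoromethoxy: a small expected step

This account rests on a few compounds, and the source may have more. Where it says the series, first, only, none or still open, it means among the compounds named here.

In a functional assay on MCF7 cells (Homo sapiens) for antiproliferative activity, read by sulforhodamine B assay, with a stated time of 48 h (on this read-out lower numbers stand for stronger inhibition and higher numbers for weaker inhibition), compound 1 (`CCc1ccc(NS(=O)(=O)c2ccc(N3CCNC3=O)cc2)cc1`) gives 810 nM, compound 2 (`O=C1NCCN1c1ccc(S(=O)(=O)Nc2ccccc2)cc1`) gives 470 nM and compound 3 (`O=C1NCCN1c1ccc(S(=O)(=O)Nc2ccc(OC(F)F)cc2)cc1`) gives 760 nM, so compound 3 stands within the scatter of both others. Compound 4 (`O=C1NCCN1c1ccc(S(=O)(=O)Nc2ccc(Br)cc2)cc1`) has bromo in place of difluoromethoxy on an aromatic carbon, para to a large group: bromo in place of difluoromethoxy on an aromatic carbon. Three measured steps exchange groups on that aromatic carbon: a 1.7-fold lower number from compound 1 to compound 2 (0.24 log units; within the scatter), a 1.1-fold lower number from compound 1 to compound 3 (0.03 log units; within the scatter) and a 1.6-fold higher number from compound 2 to compound 3 (0.21 log units; within the scatter). All three lie within the scatter, so no step beyond the scatter is expected here, in either direction. The estimated step is a 1.2-fold lower number from compound 3 to compound 4 (0.07 log units; within the scatter). For compound 4 the expected value is 650 nM, with an estimated range of 280 nM to 1500 nM.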

Compound 4, half-maximal inhibitory concentration: 240 nM
The estimate for compound 4 lay 2.7-fold (0.43 log units) above the measured number; measured number below the stated range.
By their numbers in this assay, from the lowest: compounds 4, 2, 3 and 1 (each within the scatter of the next, the first and the last beyond it).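

Among the compounds shown here, earlier exchanges on this aromatic carbon all stayed within the scatter, but bromo gives the first steps beyond it, against difluoromethoxy (a 3.2-fold lower number from compound 3 to compound 4 (0.50 log units; beyond the scatter)) and against ethyl (a 3.4-fold lower number from compound 1 to compound 4 (0.53 log units; beyond the scatter)). Against hydrogen the change stays within the scatter (a 2.0-fold lower number from compound 2 to compound 4 (0.29 log units; within the scatter)), so bromo cannot be ranked ahead of hydrogen at this position. Nothing available accounts for this result. From the compounds shown here alone, whether chloro, an amine or a carboxylic acid on this carbon would fall with bromo or with ethyl and difluoromethoxy remains open.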